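The source may hold more compounds than are shown below. What is called first, only, known or untested is meant among the compounds shown, and "the series" means these compounds.

Measured compounds:
- compound 1 `COC(=O)[C@H](CCSC)NC(=O)c1ccc(CNCc2c[nH]cn2)cc1-c1ccccc1C`: 25 uM
- compound 2 `COC(=O)[C@H](CCSC)NC(=O)c1ccc(NCc2cncn2Cc2ccc(Cl)cc2)cc1-c1ccccc1`: > 10 uM

In a functional assay on NIH3T3 cells (Mus musculus) (a lower number here means that less compound is needed, a higher number that more compound is needed for the effect), compound 1 gives 25 uM. Compound 2 stands differently on the numbers: in this assay compound 2 gives > 10 uM, which is a limit of the assay and not a number; (the limit of > 10 uM in this assay, at which 1 of the 2 values shown sits). Among the compounds with values here, compound 1 and compound 2 differ in several places at once, so no single step between them can be read, and nothing beyond their two values is said here.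

Compound 3 `COC(=O)[C@H](CCSC)NC(=O)c1ccc(NCc2cncn2Cc2ccccc2C#N)cc1-c1ccccc1` is not yet measured. It differs from compound 2 in one place only: 2-cyanophenyl in place of 4-chlorophenyl on a saturated chain carbon bound to an aromatic nitrogen. Within the data shown here, no measured step between two compounds covers this change, so there is no direct precedent for its size in this assay.

The expectation is that the step from compound 2 to compound 3 is small, none beyond the scatter, since compound 2 sits at the limit > 10 uM and the change is confined to the benzyl group on the aromatic nitrogen; the step that the limit leaves unreadable from compound 2 to compound 3 is expected accordingly. Compound 3 is therefore expected to give about 20 uM in this assay, with a range from 5 uM to 80 uM, and most likely again reported only as a limit.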

Compound 3, concentration for half-maximal effect: > 10 uM
Compound 3 was reported as a limit; the forecaster's own chance of this, stated with the estimate: 70%; the middle value lies beyond the limit too.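

In this assay compound 3 gives > 10 uM and this is a limit of the assay, not a number. Compound 2 also stands at a limit, so no step from compound 2 to compound 3 can be read: the limit of > 10 uM in this assay, at which 2 of the 3 values shown sit.

The compounds shown leave open whether 2-cyanobenzyl in place of 4-chlorobenzyl changes the value in this assay at all, and how far past the limit either compound lies.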